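The compounds below may be only part of what the source reports. "The series", "measured", "known", "first", "only" and "open" are said of these compounds alone.

Working notes on the series. Compound 2, `CN1CCN(c2ccc(Nc3nc(-c4cccc(NC(=O)c5ccc(C(C)(C)C)cc5)c4)sc3C(N)=O)cc2)CC1`, is the reference for the next step. Within the data shown here, in a functional assay on Raji cells (Homo sapiens) for antiproliferative activity, read by CCK-8 assay, with a stated time of 72 h, tested at 40 uM (a lower number here means less inhibition, a higher number more inhibition at the concentration tested (going by the name of the read-out)), compound 2 gives 12.1%; this is the higher of the two numbers so far, and the nearest is compound 1, `CCOC(=O)c1sc(-c2cccc(NC(=O)c3ccc(C(C)(C)C)cc3)c2)nc1Nc1ccc(N2CCN(C)CC2)cc1`, which in this assay gives 4.22%, a gap that lies within the scatter, so the two compounds cannot be told apart on these readings. Among the measured compounds shown here, the one measured step, a number 7.9 percentage points higher from compound 1 to compound 2 (within the scatter), concerns a change of amino in place of ethoxy on a carbonyl carbon and did not move the number beyond the scatter.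

The unmeasured compound 3, `CN1CCN(c2ccc(Nc3nc(-c4cccc(NC(=O)[C@H]5CC[C@H](C)CC5)c4)sc3C(N)=O)cc2)CC1`, differs from compound 2 at another position: 4-methylcyclohexyl in place of 4-(tert-butyl)phenyl on a carbonyl carbon. For the measured compounds named here, no measured step touches the group that leaves or the group that enters at this carbonyl carbon, so the step from compound 1 to compound 2 bears on it only indirectly, showing that a single change stayed within the scatter. On that basis a step of no size beyond the scatter is expected, a number 2.1 percentage points lower from compound 2 to compound 3 (within the scatter), with the direction open. Compound 3 is estimated at 10%, ranging from 0% to 28%.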

Compound 3, a percentage reported as inhibition, at one concentration (the size of the read-out at that concentration, not a potency): 22.4%
Estimate against measurement, compound 3: 12.4 percentage points below; measured number inside the range.
By their numbers in this assay, from the lowest: compounds 1 and 2 (each within the scatter of the next); then compound 3.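

In this assay, among these compounds, 4-methylcyclohexyl in place of 4-(tert-butyl)phenyl on a carbonyl carbon gives a number 10.3 percentage points higher from compound 2 to compound 3 (beyond the scatter), the first step to clear the scatter, so this position, where the carbonyl carbon's other neighbour is an amide-type nitrogen, can shift the read-out, which the change of amino for ethoxy on a carbonyl carbon did not show. It also shows that, in this one pair, a six-membered non-aromatic ring of carbon only at this position retains the inhibition seen with the aromatic ring and gives a modestly higher number at the single concentration tested. No evidence at hand bears on why the number rises.

The ring and its alkyl substituent change together in this step, so the pair cannot say which of the two carries the difference; a 4-methylphenyl or a plain cyclohexyl group on this carbonyl carbon would be needed to separate them. Also open, as far as these compounds go, are how the other arrangement of the two defined stereocentres would read, and whether a ring bearing an amine or a carboxylic acid at this place would hold the gain.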